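This account rests on a few compounds, and the source may have more. Where it says the series, first, only, none or still open, it means among the compounds named here.

Compound 1 `Cc1ccc(Cn2cc(CNC(=O)c3cnc(Nc4ccc(C#N)cc4)cc3Oc3c(C)cc(C)cc3C)nn2)cc1` gives 165000 nM in an ADME assay on MT4 cells (Homo sapiens) for cytotoxicity, read by MTT assay, with a stated time of 5 days; a higher number here means that more compound is tolerated, a lower number that less compound is tolerated. Compound 2 `CC(=O)Cn1cc(CNC(=O)c2cnc(Nc3ccc(C#N)cc3)cc2Oc2c(C)cc(C)cc2C)nn1` gives 19400 nM in this assay, and compound 3 `Cc1cc(C)c(Oc2cc(Nc3ccc(C#N)cc3)ncc2C(=O)NCc2cn(Cc3cccc(Cl)c3)nn2)c(C)c1` gives 187000 nM in this assay. Compound 3 thus holds the highest of the three numbers; its gap to compound 1 is within the scatter, while the step of a 9.6-fold higher number from compound 2 to compound 3 (0.98 log units; beyond the scatter) lies beyond it.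

Compound 4 `CCOC(=O)CCn1cc(CNC(=O)c2cnc(Nc3ccc(C#N)cc3)cc2Oc2c(C)cc(C)cc2C)nn1` has not yet been measured. It differs from compound 3 in one place: (ethoxycarbonyl)methyl in place of 3-chlorophenyl on a saturated chain carbon bound to an aromatic nitrogen. Going by the values given here, two measured steps bear on this change, since each exchanges an aromatic ring at the saturated chain carbon bound to the aromatic nitrogen for a chain that carries a carbonyl, or the reverse: an 8.5-fold lower number from compound 1 to compound 2 (0.93 log units; beyond the scatter) and a 9.6-fold higher number from compound 2 to compound 3 (0.98 log units; beyond the scatter). Among the compounds with values here, both point the same way, with the ring giving the higher number and the carbonyl-bearing chain the lower one, though only three compounds support this. Such a chain is present in compound 4, so in this assay a lower number is expected, of a size near those two steps, namely a 7.5-fold lower number from compound 3 to compound 4 (0.87 log units; beyond the scatter). Compound 4 is accordingly estimated at 25000 nM, with a range from 8000 nM to 80000 nM.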

Compound 4, half-maximal cytotoxic concentration: 21500 nM
Estimate against measurement, compound 4: 1.2-fold (0.07 log units) above; the range from low to high includes it.
By their numbers in this assay, from the lowest: compounds 2 and 4 (each within the scatter of the next); then compounds 1 and 3 (each within the scatter of the next).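

The new result gives the aromatic-ring-versus-carbonyl contrast at the saturated chain carbon bound to an aromatic nitrogen a second carbonyl-bearing example in this assay: the exchange of 3-chlorophenyl for (ethoxycarbonyl)methyl is a step beyond the scatter (an 8.7-fold lower number from compound 3 to compound 4 (0.94 log units; beyond the scatter)), and the comparison with the 4-methylphenyl group gives a step of similar size (a 7.7-fold lower number from compound 1 to compound 4 (0.89 log units; beyond the scatter)). Among the carbonyl-bearing groups, the identity of the chain makes no difference that can be read, since (ethoxycarbonyl)methyl and acetyl lie within the scatter of each other (a 1.1-fold higher number from compound 2 to compound 4 (0.04 log units; within the scatter)). The four compounds therefore form two pairs, with compounds 1 and 3 carrying a ring and compounds 2 and 4 carrying a carbonyl-bearing chain, and none of the four goes against this split.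

No measurement shown here accounts for the split between these two pairs. Going by these compounds, it also remains open whether the lower numbers follow the carbonyl or simply the absence of a ring, which a plain butyl chain could separate, and how a carboxylic acid or an amine at the same place would stand.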